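Swapping an Indolyl Arm for Dichlorophenyl in a Cytotoxicity Screen

The source may hold more compounds than are shown below. What is called first, only, known or untested is meant among the compounds shown, and "the series" means these compounds.

Compound 3 `CC(C)N(Cc1cccc(OCCCCCC(=O)O)c1)C(=O)c1ccc(-c2ccc3cc[nH]c3c2)cc1` was examined in an ADME assay on Raji cells (Homo sapiens) for cytotoxicity, read by CellTiter-Glo and resazurin assay, with a stated time of 72 h; on this read-out lower numbers stand for an effect already at smaller amounts and higher numbers for an effect only at larger amounts of compound. In this assay compound 3 gives only a limit of the assay, > 26000 nM. Compound 1 `CC(=O)Nc1cccc(-c2ccc(C(=O)N(Cc3cccc(OCCCCCC(=O)O)c3)C(C)C)cc2)c1`, which carries a 3-acetamidophenyl group on the same aromatic carbon, also gives only a limit in this assay, > 26000 nM. Compound 2 `CC(C)Oc1cccc(-c2ccc(C(=O)N(Cc3cccc(OCCCCCC(=O)O)c3)C(C)C)cc2)c1`, with a 3-isopropoxyphenyl group there, likewise gives only a limit in this assay, > 26000 nM. The three values therefore sit together at the ceiling of the measurement, as recorded by the limit of > 26000 nM in this assay, at which 3 of the 3 values shown sit, and the steps among them, a step that the two limits leave unreadable from compound 1 to compound 2, a step that the two limits leave unreadable from compound 1 to compound 3 and a step that the two limits leave unreadable from compound 2 to compound 3, cannot be given a size.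

Compound 4 `CC(C)N(Cc1cccc(OCCCCCC(=O)O)c1)C(=O)c1ccc(-c2ccc(Cl)c(Cl)c2)cc1` has not yet been measured. It differs from compound 3 in one place: 3,4-dichlorophenyl in place of 1H-indol-6-yl on an aromatic carbon. For the measured compounds named here, none of the measured steps puts a 3,4-dichlorophenyl group on that aromatic carbon, so no step speaks to this change directly; what the three measured compounds show is that three different groups at this position all left the value at the limit. The step that the limit leaves unreadable from compound 3 to compound 4 is therefore estimated to be none beyond the scatter, with a further limit the likeliest outcome. Compound 4 is expected to give 30000 nM in this assay, with a range from 10000 nM to 100000 nM.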

Compound 4, half-maximal effective concentration: > 26000 nM
Compound 4 ended at the assay's limit; the forecaster's own chance of this, stated with the estimate: 75%; the middle value does not contradict the limit.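

For the compounds shown here, no step from compound 1, compound 2 or compound 3 to compound 4 can be read in this assay, because all of them end at one ceiling: the limit of > 26000 nM in this assay, at which 4 of the 4 values shown sit. The compounds shown leave open how far each lies from that limit, and whether any group on this aromatic carbon would give a measurable value.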